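The source may report more compounds than this note shows. Statements on the series, on what has been measured and on what is new or still open speak of the compounds shown alone.

Compound 1 `COc1ccc(N(C)c2ccnc(Cl)n2)cc1F` is one of three analogues on a shared core tested in a functional assay on A549 cells (Homo sapiens) for antiproliferative activity, read by MTT assay, with a stated time of 48 h; a higher number here means a weaker inhibitor, a lower number a stronger inhibitor. In this assay compound 1 gives 651 nM, the highest of the three numbers, though neither of the others is separated from it beyond the scatter. Compound 2 `COc1ccc(N(C)c2ccnc(Cl)n2)cc1Cl` gives 621 nM, and compound 3 `COc1ccc(N(C)c2ccnc(Cl)n2)cc1OCC[Se]C#N` gives 463 nM. The steps from compound 1 are a 1.0-fold lower number from compound 1 to compound 2 (0.02 log units; within the scatter) and a 1.4-fold lower number from compound 1 to compound 3 (0.15 log units; within the scatter); between the other pair the step is a 1.3-fold lower number from compound 2 to compound 3 (0.13 log units; within the scatter). Compound 4 `COc1ccc(N(C)c2ccnc(Cl)n2)cc1OCCC[Se]C#N` has not yet been measured in this assay. It differs from compound 1 in one place: a group of 7 heavy atoms (4 carbon, 1 nitrogen, 1 oxygen, 1 selenium; no ring) in place of one fluorine atom, on an aromatic carbon. The closest guide is the replacement of the same fluorine atom in compound 3, which stayed within the scatter, and the replacement in compound 2 at that carbon did likewise. The expected step is therefore a 1.4-fold lower number from compound 1 to compound 4 (0.13 log units; within the scatter), none beyond the scatter, because a 1.4-fold lower number from compound 1 to compound 3 (0.15 log units; within the scatter). The estimated value for compound 4 in this assay is 480 nM, with a range from 240 nM to 950 nM.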

Compound 4, half-maximal inhibitory concentration: 3710 nM
The estimate for compound 4 lay 7.7-fold (0.89 log units) below the measured number, and the stated range ends below it.
By their numbers in this assay, from the lowest: compounds 3, 2 and 1 (each within the scatter of the next); then compound 4.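

Lengthening the selenium-bearing chain at the carbon ortho to a methoxy group is not a neutral change: this alone gives an 8.0-fold higher number from compound 3 to compound 4 (0.90 log units; beyond the scatter) in this assay, although the chain of compound 3 had stayed within the scatter of both halogen compounds. Measured against those halogen compounds, the longer chain gives a 5.7-fold higher number from compound 1 to compound 4 (0.76 log units; beyond the scatter) and a 6.0-fold higher number from compound 2 to compound 4 (0.78 log units; beyond the scatter) at the same carbon, so this position does not accept every chain alike. The compounds shown offer no measurement that accounts for this shift.

With only two chain lengths shown, it remains open whether a still longer chain would go further in the same direction or return towards compound 3. From the compounds shown here alone, it is also open whether a chain ending in an amine or a carboxylic acid, in place of the selenium and nitrile, would follow compound 3 or compound 4.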